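Thieno-fused pyridyl ureas: aryl substituent swap in HUVEC proliferation

A few compounds are considered here, and "the series" means these few. Any claim that something is new, unique, unknown or untested is made for them only; others in the source may bear on it.

Three measured compounds share one core. Compound 1 `Cc1cccc(NC(=O)Nc2nnc(Sc3ncnc4scc(-c5ccncc5)c34)s2)c1` gives 12200 nM in a functional assay on HUVEC cells (Homo sapiens) for antiproliferative activity, read by MTT assay, with a stated time of 48 h; a lower number here means a stronger inhibitor, a higher number a weaker inhibitor; compound 2 `O=C(Nc1cccc(C(F)(F)F)c1)Nc1nnc(Sc2ncnc3scc(-c4ccncc4)c23)s1` gives 22400 nM; compound 3 `O=C(Nc1ccc(Cl)c(Cl)c1)Nc1nnc(Sc2ncnc3scc(-c4ccncc4)c23)s1` gives 7800 nM. Compound 2 holds the highest number of the three, though the gap to compound 1 is small, a 1.8-fold higher number from compound 1 to compound 2 (0.26 log units; within the scatter), and only the gap to compound 3 is real, a 2.9-fold lower number from compound 2 to compound 3 (0.46 log units; beyond the scatter). Compound 4 `O=C(Nc1cccc(F)c1)Nc1nnc(Sc2ncnc3scc(-c4ccncc4)c23)s1` differs from compound 2 by fluoro in place of trifluoromethyl on an aromatic carbon. The step from methyl to trifluoromethyl bears on this, as does the drop to compound 3; both point toward a lower number for a smaller group, but only weakly. Compound 4 is therefore expected to show a 1.6-fold lower number from compound 2 to compound 4 (0.20 log units; within the scatter), estimated at 14000 nM with a range of 6000 nM to 30000 nM.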

Compound 4, half-maximal inhibitory concentration: 13700 nM
Estimate against measurement, compound 4: 1.0-fold (0.01 log units) above, and the stated range covers the measured number.
By their numbers in this assay, from the lowest: compounds 3, 1, 4 and 2 (each within the scatter of the next, the first and the last beyond it).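

In this assay fluoro on this aromatic carbon stays within the scatter of all three earlier compounds, with a 1.6-fold lower number from compound 2 to compound 4 (0.21 log units; within the scatter) and a 1.1-fold higher number from compound 1 to compound 4 (0.05 log units; within the scatter) and a 1.8-fold higher number from compound 3 to compound 4 (0.24 log units; within the scatter) as the steps. Going from 4 heavy atoms to 1 at this place therefore gives no readable change, and compound 4 separates from neither compound 2 nor compound 3, although those two lie beyond the scatter of each other. No measurement at hand offers an explanation for this flat response.

From the compounds shown here alone, whether an amine or a carboxylic acid here would move the number beyond the scatter remains open. A 3-chlorophenyl group would show whether one chlorine alone matches the 3,4-dichlorophenyl of compound 3.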